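The source may report more compounds than this note shows. Statements on the series, on what has been measured and on what is new or still open speak of the compounds shown alone.

Among the compounds with values here, compound 2 `O=C(Nc1c(C(O)(C(F)(F)F)C(F)(F)F)ccc2ccccc12)c1ccc(Br)cc1` has, in an assay on LtK cells with ATP-sensitive inward rectifier potassium channel 11 (Homo sapiens) as the target (on this read-out higher numbers stand for an effect only at larger amounts of compound and lower numbers for an effect already at smaller amounts), the lowest of the two numbers measured so far, giving 47 nM. Within the data shown here, the only other measured compound is compound 1 `O=C(Nc1ccc(Cl)cc1)Nc1c(C(O)(C(F)(F)F)C(F)(F)F)ccc2ccccc12`, which in this assay gives 276 nM. Among the measured compounds shown here, the one measured step, a 5.9-fold lower number from compound 1 to compound 2 (0.77 log units; beyond the scatter), came from a change at the carbonyl carbon, where 4-bromophenyl took the place of (4-chlorophenyl)amino.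

Compound 3 `O=C(Nc1c(C(O)(C(F)(F)F)C(F)(F)F)ccc2ccccc12)c1ccco1` again alters the group on that carbonyl carbon: furan-2-yl in place of 4-bromophenyl on a carbonyl carbon. This is the same position as in the measured step, so that step bears on it, but only loosely: it swapped an amino-linked ring for a directly attached one, whereas here one directly attached aromatic ring gives way to another, a furan-2-yl with a hetero atom and one hydrogen-bond acceptor in place of 4-bromophenyl. For the measured compounds named here, no measured pair shows what such a ring exchange does here. A step of uncertain direction, plausibly within or only just beyond the scatter, is therefore expected, and in this assay the change from compound 2 to compound 3 is estimated at a 3.2-fold higher number from compound 2 to compound 3 (0.50 log units; beyond the scatter). Compound 3 is expected to give about 150 nM in this assay, within a range from 40 nM to 600 nM.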

Compound 3, half-maximal effective concentration: 9 nM
Compound 3: middle estimate off by 17-fold (1.22 log units), on the high side; the whole stated range lies above it.
By their numbers in this assay, from the lowest: compound 3; then compound 2; then compound 1.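

In this assay the ring on the carbonyl carbon matters in its own right: with the amide-type nitrogen kept and furan-2-yl in place of 4-bromophenyl, the result is a 5.2-fold lower number from compound 2 to compound 3 (0.72 log units; beyond the scatter), a step beyond the scatter. The earlier step, a 5.9-fold lower number from compound 1 to compound 2 (0.77 log units; beyond the scatter), had changed the amino link and the ring together, so it could not show what the directly attached ring does alone; now a change of that ring alone also lowers the number. Taken together, the two changes at this position give a 31-fold lower number from compound 1 to compound 3 (1.49 log units; beyond the scatter), which makes compound 3, with the smaller five-membered ring carrying a hetero atom, the compound with the lowest number of the three.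

Which difference counts remains open, whether the oxygen in the ring, the five-membered ring itself or the loss of the bromine, and a thiophen-2-yl or an unsubstituted phenyl on the same carbonyl carbon would help to separate these. Nothing available here explains why furan-2-yl gives the lower number.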